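Cyclopropylamino for cyclohexylsulfanyl on the shared core

A few compounds are considered here, and "the series" means these few. Any claim that something is new, unique, unknown or untested is made for them only; others in the source may bear on it.

Compound 1 `Cc1cc(SC2CCCCC2)nc(Nc2ccc(C#N)cc2)n1` and compound 2 `Cc1cnc(Nc2ccc(C#N)cc2)nc1SC1CCCCC1` share the core. In an ADME assay on MT4 cells (Homo sapiens) for cytotoxicity, read by MTT assay (a higher number here means that more compound is tolerated, a lower number that less compound is tolerated), compound 1 gives only a limit of the assay, >= 192000 nM, not a number. Compound 1 stands at the limit of >= 192000 nM in this assay, at which 1 of the 2 values shown sits. In this assay compound 2 gives 33400 nM. The values of compound 1 and compound 2 stand well apart.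

Compound 3 `Cc1cc(NC2CC2)nc(Nc2ccc(C#N)cc2)n1` differs from compound 1 by cyclopropylamino in place of cyclohexylsulfanyl on an aromatic carbon. For the measured compounds named here, no measured step covers such a change; in this assay the step from compound 1 to compound 3 is expected to be small, none beyond the scatter, an at least 1.2-fold lower number from compound 1 to compound 3 (0.10 log units; that floor lies within the scatter). Compound 3 is estimated at 150000 nM, within 40000 nM to 400000 nM.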

Compound 3, half-maximal cytotoxic concentration: 88 nM
Compound 3: the middle estimate sits 1700-fold (3.23 log units) above what was measured; measured number outside the range, below it.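

In this assay, cyclopropylamino in place of cyclohexylsulfanyl on an aromatic carbon gives an at least 2100-fold lower number from compound 1 to compound 3 (3.33 log units; beyond the scatter), so a single change at this position can move tolerance on the shared core by a very wide margin. The size of that step is only a floor, since compound 1 gives a limit of the assay and not a number: the limit of >= 192000 nM in this assay, at which 1 of the 3 values shown sits.

The change swaps the linking atom and the ring together, and the compounds shown do not separate the two. Cyclohexylamino or cyclopropylsulfanyl at this position would tell them apart.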